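Methoxy in place of methyl on the shared core

A few compounds are considered here, and "the series" means these few. Any claim that something is new, unique, unknown or untested is made for them only; others in the source may bear on it.

Measured in a functional assay on HCT-116 cells (Homo sapiens), read by MTT assay, with a stated time of 3 days; a lower number here means a stronger inhibitor, a higher number a weaker inhibitor:
- compound 1 `c1coc(-c2ncnc3[nH]cc(Sc4cccs4)c23)c1`: 19500 nM
- compound 2 `Cc1ncnc2[nH]cc(Sc3cccs3)c12`: 29100 nM

For the measured compounds named here, only two compounds have numbers so far. Compound 2 gives 29100 nM, within the scatter of compound 1, so no order can be drawn between them.

The next compound is compound 3 `COc1ncnc2[nH]cc(Sc3cccs3)c12`, with methoxy in place of methyl on an aromatic carbon.

Going by the values given here, one measured step bears on this change. It alters the same aromatic carbon and exchanges furan-2-yl for methyl: a 1.5-fold higher number from compound 1 to compound 2 (0.17 log units; within the scatter). That step stays within the scatter, though it is a single step and does not involve methoxy, so it offers only weak guidance. With nothing pointing to a larger shift in this assay, no step beyond the scatter is expected, and no direction can be assigned. The expected result is a 1.2-fold lower number from compound 2 to compound 3 (0.07 log units; within the scatter).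

For compound 3 the estimate is 25000 nM, with an expected range of 11000 nM to 55000 nM.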

Compound 3, half-maximal inhibitory concentration: > 50000 nM
Compound 3: a limit, no number; the forecaster's own chance of this, stated with the estimate: 10%; at least 2.0-fold (0.30 log units) between middle value and limit.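

Compound 3 carries a limit in this assay, not a number: the limit of > 50000 nM in this assay, at which 1 of the 3 values shown sits. Against furan-2-yl, methoxy on this aromatic carbon gives the only step in the series so far that clears the scatter, an at least 2.5-fold higher number from compound 1 to compound 3 (0.40 log units; beyond the scatter), so this position is no longer silent in the way the step between the two earlier compounds suggested. Against methyl the reading is less firm, an at least 1.7-fold higher number from compound 2 to compound 3 (0.23 log units; that floor lies within the scatter), and that floor alone does not separate methoxy from methyl, although the real gap may be larger than the floor.

From the compounds shown here alone, how far compound 3 lies past its limit stays open, so the true size of both methoxy steps is unknown, and with all three compounds this high in the assay the position has yet to show any change that lowers the number. Going by these compounds, whether an amine or a longer alkoxy chain on this same aromatic carbon would give a readable number, and on which side of compound 1 and compound 2 it would fall, also stays open.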